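Swapping the aniline group on a pyrimidine core

The source may report more compounds than this note shows. Statements on the series, on what has been measured and on what is new or still open speak of the compounds shown alone.

Measured compounds:
- compound 1, `CN(c1cccc2c1CN(c1nc(Nc3ccc(Cl)c(C(F)(F)F)c3)ncc1C(F)(F)F)C2)S(C)(=O)=O`, 11100 nM
- compound 2, `COc1cc(N2CCN(C(C)=O)CC2)ccc1Nc1ncc(C(F)(F)F)c(N2Cc3cccc(N(C)S(C)(=O)=O)c3C2)n1`, 1300 nM
- compound 3, `CN(c1cccc2c1CN(c1nc(Nc3cccc(Oc4ccccc4)c3)ncc1C(F)(F)F)C2)S(C)(=O)=O`, 4300 nM

In a functional assay on HeLa cells (Homo sapiens) for antiproliferative activity, read by spectrophotometry, with a stated time of 2 days (a higher number here means a weaker inhibitor of growth, a lower number a stronger inhibitor of growth), compound 1 gives the highest number of the three, so it is the weakest inhibitor of growth among them; compound 3 sits at a lower number, and compound 2 at the lowest.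

Compound 4, `Cc1cc(C)cc(Nc2ncc(C(F)(F)F)c(N3Cc4cccc(N(C)S(C)(=O)=O)c4C3)n2)c1`, has not been measured. It differs from compound 1 in a single place: 3,5-dimethylphenyl in place of 4-chloro-3-(trifluoromethyl)phenyl on a nitrogen on an aromatic ring. Within the data shown here, no pair of measured compounds shows this exact change, so the size of the step is uncertain. The two compounds with other groups on that nitrogen both give lower numbers than compound 1, which suggests compound 4 may also move toward a lower number, though perhaps not beyond the scatter. The expected step of a 1.6-fold lower number from compound 1 to compound 4 (0.20 log units; within the scatter) is modest. For compound 4 the estimate in this assay is 7000 nM, with a range from 2500 nM to 20000 nM.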

Compound 4, concentration for 50% growth inhibition: > 30000 nM
Compound 4 was reported as a limit (the forecaster's own chance of this, stated with the estimate: 10%); middle value at least 4.2-fold (0.63 log units) from the limit.
By their numbers in this assay, from the lowest: compound 2; then compound 3; then compound 1. At a limit, above all of these: compound 4.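

Putting 3,5-dimethylphenyl in place of 4-chloro-3-(trifluoromethyl)phenyl on this nitrogen gives, in this assay, an at least 2.7-fold higher number from compound 1 to compound 4 (0.43 log units; beyond the scatter). Among these compounds, this is the first single-place comparison here, and it shows that exchanging one substituted phenyl for another on this nitrogen can weaken growth inhibition. Compound 4 is reported only as a limit, not as a number: the limit of > 30000 nM in this assay, at which 1 of the 4 values shown sits.

Going by these compounds, how far the step truly extends remains open. So does whether a phenyl carrying only a chlorine, or one carrying a carboxylic acid or a morpholine, would give a lower number than compound 1.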